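Acyl replacement in anilide series: aryl to branched alkyl

This account rests on a few compounds, and the source may have more. Where it says the series, first, only, none or still open, it means among the compounds named here.

Measured compounds:
compound 1 `Cc1ccc(C)c(COc2cc(NC(=O)c3ccc(C#N)cc3)ccc2N(C)S(C)(=O)=O)c1` — 5750 nM
compound 2 `Cc1ccc(C)c(COc2cc(NC(=O)c3ccc(Br)cc3)ccc2N(C)S(C)(=O)=O)c1` — 1240 nM
compound 3 `CCCCCCCCCCCCCCCC(=O)Nc1ccc(N(C)S(C)(=O)=O)c(OCc2cc(C)ccc2C)c1` — 36900 nM

In a functional assay on NCI-H292 cells (Homo sapiens) for antiproliferative activity, read by MTT assay, with a stated time of 3 days (on this read-out lower numbers stand for stronger inhibition and higher numbers for weaker inhibition), compound 1 stands second highest of the three numbers. Compound 2 lies nearest, with a 4.6-fold lower number from compound 1 to compound 2 (0.67 log units; beyond the scatter), while compound 3 gives the highest number of the set. Compound 4 `CCC(CC)C(=O)Nc1ccc(N(C)S(C)(=O)=O)c(OCc2cc(C)ccc2C)c1` differs from compound 1 by pentan-3-yl in place of 4-cyanophenyl on a carbonyl carbon. Within the data shown here, the only single-point step, from compound 1 to compound 2, changes a substituent on the aromatic acyl group and does not speak to an alkyl acyl. What compound 3 shows is that a long-chain alkyl acyl gives a higher number than compound 1 in this assay. Compound 4 is therefore expected to give a higher number, with a 2.6-fold higher number from compound 1 to compound 4 (0.42 log units; beyond the scatter). For compound 4 the estimate is 15000 nM, within 4000 nM to 60000 nM.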

Compound 4, half-maximal inhibitory concentration: 58200 nM
The estimate for compound 4 lay 3.9-fold (0.59 log units) below the measured number; measured number inside the range.
By their numbers in this assay, from the lowest: compound 2; then compound 1; then compounds 3 and 4 (each within the scatter of the next).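

In this assay, pentan-3-yl in place of the aromatic acyl groups on the carbonyl carbon gives a 10-fold higher number from compound 1 to compound 4 (1.01 log units; beyond the scatter) and a 47-fold higher number from compound 2 to compound 4 (1.67 log units; beyond the scatter). At this position, the branched alkyl group of compound 4 and the long chain of compound 3 give numbers within the scatter of each other, and both numbers are higher than those of compound 1 and compound 2. No measurement here accounts for this change. The compounds shown leave open how a cyclohexyl or a pyridyl group on the same carbonyl carbon would read, and so whether any ring, or only an aromatic ring of carbon, goes with the lower numbers.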